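Swapping a dimethoxyphenyl for a trifluoromethylphenyl group

The source may report more compounds than this note shows. Statements on the series, on what has been measured and on what is new or still open speak of the compounds shown alone.

Of the compounds shown here, three sharing one five-membered core have been tested in a functional assay on BGC-823 cells (Homo sapiens) for antiproliferative activity, read by MTT assay, tested at 1 uM; on this read-out higher numbers stand for a stronger effect at the one concentration tested and lower numbers for a weaker effect. Compound 1 `COc1cc(C2=NN(C(C)=O)C(c3c(Cl)cccc3Cl)O2)cc(OC)c1OC` gives -1.4%. Compound 2 `COc1ccc(C2OC(c3cc(OC)c(OC)c(OC)c3)=NN2C(C)=O)c(OC)c1` gives 6.3%, and compound 3 `COc1ccc(OC)c(C2OC(c3cc(OC)c(OC)c(OC)c3)=NN2C(C)=O)c1` gives 0.4%. All three numbers lie within the usual scatter of one another, so compound 3 does not stand apart from either of the others. Compound 4 `COc1cc(C2=NN(C(C)=O)C(c3ccccc3C(F)(F)F)O2)cc(OC)c1OC` differs from compound 3 in one place: 2-(trifluoromethyl)phenyl in place of 2,5-dimethoxyphenyl on a saturated ring carbon. The step that bears most on this change is a number 1.8 percentage points higher from compound 1 to compound 3 (within the scatter). That step too exchanged the 2,6-dichlorophenyl group, which carries no methoxy groups, for the 2,5-dimethoxyphenyl group, and the read-out did not move beyond the scatter. The other aryl exchanges, a number 7.7 percentage points higher from compound 1 to compound 2 (within the scatter) and a number 5.9 percentage points lower from compound 2 to compound 3 (within the scatter), also stayed within the scatter. No step beyond the scatter is therefore expected in this assay, and the expected step is a number 1.6 percentage points higher from compound 3 to compound 4 (within the scatter). Compound 4 is estimated to give 2%, with a range from -8% to 12%.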

Compound 4, a percentage reported as inhibition, at one concentration (the size of the read-out at that concentration, not a potency): 31.8%
Compound 4: middle estimate off by 29.8 percentage points, on the low side; measured number above the stated range.
By their numbers in this assay, from the lowest: compounds 1, 3 and 2 (each within the scatter of the next); then compound 4.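

In this assay, the earlier aryl exchanges on this saturated ring carbon all stayed within the scatter, but 2-(trifluoromethyl)phenyl changes the picture: the read-out is a number 31.4 percentage points higher from compound 3 to compound 4 (beyond the scatter), a number 25.5 percentage points higher from compound 2 to compound 4 (beyond the scatter) and a number 33.2 percentage points higher from compound 1 to compound 4 (beyond the scatter). This position can therefore affect the read-out, and losing the methoxy groups is not enough on its own, since the 2,6-dichlorophenyl group of compound 1 also has none and does not stand out from compound 2 or compound 3. Nothing available here explains why 2-(trifluoromethyl)phenyl stands apart.

The compounds shown leave open whether the trifluoromethyl group itself is needed, as they include no plain phenyl ring and no ring carrying a methyl group or a nitrile in its place. With a single test concentration, they also leave the potency of compound 4 open.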